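The compounds below may be only part of what the source reports. "The series", "measured", "known", "first", "only" and "open" are said of these compounds alone.

Three members of one amide series have been tested for cytotoxicity. Compound 1 `O=C(Nc1cccc(Oc2ccccn2)c1)C1CCCN(C(=O)c2cc(C(F)(F)F)cc(C(F)(F)F)c2)C1` gives, in an ADME assay on PC-3 cells (Homo sapiens) for cytotoxicity, read by WST assay, tested at 100 uM (a higher number here means more inhibition at the concentration tested (going by the name of the read-out), a lower number less inhibition), a reading of 0%. Compound 2 `N#Cc1cccc(C(=O)N2CCCC(C(=O)Nc3ccc(Cl)cc3)C2)c1` gives 0% in this assay, and compound 3 `O=C(Nc1cccc(Oc2ccccc2)c1)C1CCCN(C(=O)c2cccc(-c3ccco3)c2)C1` gives 0%. On these numbers compound 1 stands level with compound 2 and with compound 3: none of the three readings is separated from another by more than the usual scatter, so no ordering among them can be drawn.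

The next compound, compound 4 `COC(=O)c1cc(-c2cccc(NC(=O)C3CCCN(C(=O)c4cc(C(F)(F)F)cc(C(F)(F)F)c4)C3)c2)co1`, is built from compound 1 by a single exchange on the shared core: 5-(methoxycarbonyl)furan-3-yl in place of (pyridin-2-yl)oxy on an aromatic carbon. Going by the values given here, no pair of measured compounds differs in just one place, so there is no measured step of this kind to lean on, and the change has to be judged from the three flat readings alone.

With every measured compound at the same level, the expectation is that the step of a number 3 percentage points higher from compound 1 to compound 4 (within the scatter) stays within the scatter. Compound 4 is therefore expected to read about 3%, with a likely range from -5% to 20%.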

Compound 4, a percentage reported as inhibition, at one concentration (the size of the read-out at that concentration, not a potency): 0%
Compound 4: the middle estimate sits 3 percentage points above what was measured; measured number inside the range.
By their numbers in this assay, from the lowest: compounds 1, 2, 3 and 4 (each within the scatter of the next).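

In this assay the series now has its first step at a single place, with no change at the digits printed from compound 1 to compound 4 (within the scatter) as 5-(methoxycarbonyl)furan-3-yl replaces (pyridin-2-yl)oxy on the aromatic carbon. This shows that the position, meta to a large group, can carry a five-membered aromatic ring with a methoxycarbonyl group in place of a six-membered aromatic ring joined through oxygen, and the reading still shows no inhibition at the one concentration tested. Nothing available bears on why the reading stays the same.

From the compounds shown here alone, since both compounds of the step read the same, it remains open whether any group at this position can move the reading at all. An amine or a carboxylic acid on this aromatic carbon would be a different kind of change, and the compounds shown say nothing about either.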